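The source may report more compounds than this note shows. Statements on the series, on what has been measured and on what is new or still open speak of the compounds shown alone.

Compound 1 `COc1ccc(S(=O)(=O)NCCCNc2nccc(-c3c(-c4cccc(F)c4)nc4sccn34)n2)cc1` sits in the middle of a small set of three compounds that share one core and differ only in the arylsulfonyl or aroyl group on the side chain. In a functional assay on SK-MEL-28 cells (Homo sapiens) for cytotoxicity, read by MTT assay (on this read-out lower numbers stand for stronger inhibition and higher numbers for weaker inhibition), compound 1 gives 8980 nM, the second highest of the three numbers; compound 2 `O=C(NCCNc1nccc(-c2c(-c3cccc(F)c3)nc3sccn23)n1)c1ccc(Cl)cc1` gives 8160 nM, within the scatter of compound 1, and compound 3 `O=C(NCCNc1nccc(-c2c(-c3cccc(F)c3)nc3sccn23)n1)c1ccccc1` gives 17000 nM, also within the scatter of compound 1, so no order among the three can be read from these values.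

Compound 4 `O=S(=O)(NCCCNc1nccc(-c2c(-c3cccc(F)c3)nc3sccn23)n1)c1ccccc1` is the new compound. The change from compound 1 to compound 4 is hydrogen in place of methoxy on an aromatic carbon. Among the measured compounds shown here, the only measured step that touches a substituent on the same kind of ring is a 2.1-fold higher number from compound 2 to compound 3 (0.32 log units; beyond the scatter), which removed a chloro rather than a methoxy and did so on an aroyl rather than an arylsulfonyl group, so it bears on the present step only loosely. Taken at face value it suggests that removing the para substituent raises the number modestly. A step of similar size is therefore expected here, a 1.6-fold higher number from compound 1 to compound 4 (0.19 log units; within the scatter), though one that may well fall within the scatter. Compound 4 is thus estimated at 14000 nM, with a range from 6500 nM to 30000 nM.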

Compound 4, half-maximal inhibitory concentration: 6850 nM
Compound 4: middle estimate off by 2.0-fold (0.31 log units), on the high side; measured number inside the range.
By their numbers in this assay, from the lowest: compounds 4, 2, 1 and 3 (each within the scatter of the next, the first and the last beyond it).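

In this assay, among the compounds shown here, the step at this position is a 1.3-fold lower number from compound 1 to compound 4 (0.12 log units; within the scatter), so on the phenylsulfonyl side chain the loss of the methoxy group gives no change that can be told from the scatter, whereas the one earlier step that removed a ring substituent, the chloro of compound 2, was a 2.1-fold higher number from compound 2 to compound 3 (0.32 log units; beyond the scatter). The new compound also allows the two side chains to be set against each other, and here the outcome depends on the partner: ((phenylsulfonyl)amino)methyl in place of benzamido gives a 2.5-fold lower number from compound 3 to compound 4 (0.39 log units; beyond the scatter), while the same group in place of ((4-chlorophenyl)carbonyl)amino gives a 1.2-fold lower number from compound 2 to compound 4 (0.08 log units; within the scatter). Nothing at hand explains why the methoxy group can be lost without a readable change or why the side-chain exchange reads differently against the two partners.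

Going by these compounds, whether an amine or a carboxylic acid at this place on the phenylsulfonyl ring would shift the number beyond the scatter remains open. Also open, on these data alone, is how much of the side-chain step belongs to the sulfonyl group and how much to the extra methylene, and whether a longer chain would change the number at all.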